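Biaryl imidazolines at the alpha-2B receptor: hydroxy to methyl

This account rests on a few compounds, and the source may have more. Where it says the series, first, only, none or still open, it means among the compounds named here.

Measured compounds: compound 1 `CC(Oc1ccccc1-c1ccncc1)C1=NCCN1` gives 2690 nM; compound 2 `CC(Oc1ccccc1-c1ccccc1[N+](=O)[O-])C1=NCCN1` gives 1550 nM; compound 3 `CC(Oc1ccccc1-c1ccccc1O)C1=NCCN1` gives 1000 nM.

In an assay on CHO cells for displacement of a labelled ligand from Alpha-2B adrenergic receptor (Homo sapiens) (a lower number here means a stronger inhibitor, a higher number a weaker inhibitor), compound 3 has the lowest number of the three. The step of a 2.7-fold lower number from compound 1 to compound 3 (0.43 log units; beyond the scatter) lies beyond the scatter, whereas the step of a 1.6-fold lower number from compound 2 to compound 3 (0.19 log units; within the scatter) does not, so compound 3 and compound 2 cannot be separated.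

Compound 4 `Cc1ccccc1-c1ccccc1OC(C)C1=NCCN1` differs from compound 3 by methyl in place of hydroxy on an aromatic carbon. Both measured steps concern the arrival of hydroxy at this position, from pyridin-4-yl or from nitro; neither removes it in favour of methyl, so the bearing is indirect. The two steps were modest or within the scatter, and all three numbers span a narrow band. The step to compound 4 is therefore expected to be small, most likely a somewhat higher number, as a 1.6-fold higher number from compound 3 to compound 4 (0.20 log units; within the scatter). For compound 4 the estimated value in this assay is 1600 nM, with a range from 500 nM to 5000 nM.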

Compound 4, inhibition constant: 832 nM
Compound 4: middle estimate off by 1.9-fold (0.28 log units), on the high side, and the stated range covers the measured number.
By their numbers in this assay, from the lowest: compounds 4, 3, 2 and 1 (each within the scatter of the next, the first and the last beyond it).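

In this assay, replacing the hydroxy with methyl removes a hydrogen-bond donor and a hydrogen-bond acceptor, yet the step, a 1.2-fold lower number from compound 3 to compound 4 (0.08 log units; within the scatter), stays within the scatter, so this change does not separate the two compounds. The step of a 1.9-fold lower number from compound 2 to compound 4 (0.27 log units; within the scatter) also lies within the scatter, which leaves hydroxy, nitro and methyl on this aromatic carbon indistinguishable, whereas the step of a 3.2-fold lower number from compound 1 to compound 4 (0.51 log units; beyond the scatter) lies beyond it, as the earlier step from that compound to compound 3 did. Nothing available explains why these groups give such similar numbers.

The compounds shown leave open whether an amine, a carboxylic acid or a longer chain such as ethyl on this carbon would stay in the same narrow band. They also leave open whether any group here could move the number well below it.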